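The compounds below may be only part of what the source reports. "The series", "measured", "known", "first", "only" and "open" are said of these compounds alone.

Compound 1 `CC(C)[C@H](NC(=O)COc1cccc2ccccc12)C(=O)N[C@@H](CC(=O)O)C(=O)CSc1ncc[nH]1` was examined in a functional assay on Jurkat cells (Homo sapiens) for inhibition; on this read-out lower numbers stand for stronger inhibition and higher numbers for weaker inhibition. In this assay compound 1 gives > 200000 nM, and this is a limit of the assay rather than a measured number. Compound 1 therefore stands only at a limit among the values shown, and its two close relatives do the same. Compound 2 `CC(C)[C@H](NC(=O)COc1cccc2ccccc12)C(=O)N[C@@H](CC(=O)O)C(=O)COc1nc2ccccc2[nH]1` gives > 200000 nM in this assay, again a limit. Compound 3 `CC(C)[C@H](NC(=O)COc1cccc2ccccc12)C(=O)N[C@@H](CC(=O)O)C(=O)COc1ccncn1` gives > 200000 nM in this assay, also a limit. The steps between these three cannot be read in size: a step that the two limits leave unreadable from compound 1 to compound 2, a step that the two limits leave unreadable from compound 1 to compound 3 and a step that the two limits leave unreadable from compound 2 to compound 3. All three sit at the limit of > 200000 nM in this assay, at which 3 of the 3 values shown sit.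

Compound 4 `Cc1cc(OCC(=O)[C@H](CC(=O)O)NC(=O)[C@@H](NC(=O)COc2cccc3ccccc23)C(C)C)nc(C)n1` differs from compound 1 in one place: (2,6-dimethylpyrimidin-4-yl)oxy in place of (1H-imidazol-2-yl)sulfanyl on a saturated chain carbon bound to a carbonyl carbon. For the measured compounds named here, the step from compound 1 to compound 3 is the one that resembles this change most closely, and it is unreadable. Compound 4 is expected to stay beyond the limit too because the three measured compounds all sit at the limit of > 200000 nM in this assay, at which 3 of the 3 values shown sit. For compound 4 the expected step is a step that the limit leaves unreadable from compound 1 to compound 4. Compound 4 is estimated at 300000 nM, within 50000 nM to 2000000 nM.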

Compound 4, half-maximal inhibitory concentration: > 200000 nM
Compound 4: a limit, no number (the forecaster's own chance of this, stated with the estimate: 85%); the middle value lies beyond the limit too.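

For the compounds shown here, compound 4 also ends at a limit, so no step linking it to compound 1, compound 2 or compound 3 can be read in size: the limit of > 200000 nM in this assay, at which 4 of the 4 values shown sit. The compounds shown leave open which group on the saturated chain carbon, if any, would give a measurable value in this assay.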